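Clearance at one ring nitrogen: compound 2 to compound 3

A few compounds are considered here, and "the series" means these few. Any claim that something is new, unique, unknown or untested is made for them only; others in the source may bear on it.

Within the data shown here, in an ADME assay on microsomes from liver (Mus musculus) for metabolic stability, read by LC-MS, using NADPH, with a stated time of 10 min, tested at 0.1 uM (on this read-out lower numbers stand for slow clearance and higher numbers for fast clearance), compound 1 (`COc1ccc(F)cc1N1C(=O)CSC1c1cccc(C(=O)NCCCCc2ccccc2)c1`) stands at 2250 mL.min-1.g-1 and compound 2 (`O=C(NCCCCc1ccccc1)c1cccc(C2SCC(=O)N2c2cccc(-c3c[nH]nn3)c2)c1`) at 951 mL.min-1.g-1 as the lower of the two numbers so far. Compound 3 (`O=C(NCCCCc1ccccc1)c1cccc(C2SCC(=O)N2c2ccccn2)c1`) has not yet been measured, and going to it brings a group of 6 heavy atoms (5 carbon, 1 nitrogen; one six-membered aromatic ring with 1 hetero atom) in place of a group of 11 heavy atoms (8 carbon, 3 nitrogen; one five-membered aromatic ring with 3 hetero atoms, one six-membered aromatic ring of carbon only), on an amide-type nitrogen in a ring in the same place as the earlier change. Among the measured compounds shown here, only one measured step bears on this: a 2.4-fold lower number from compound 1 to compound 2 (0.37 log units; beyond the scatter) was modest but beyond the scatter, and it arrived at the very group that now leaves. With that single step as a guide, a smaller move back toward faster clearance is expected, one that may not leave the scatter. The estimate thus means a 1.5-fold higher number from compound 2 to compound 3 (0.17 log units; within the scatter) as the expected step. In this assay compound 3 is estimated at 1400 mL.min-1.g-1 with a range from 700 mL.min-1.g-1 to 2800 mL.min-1.g-1 as the expected span.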

Compound 3, intrinsic clearance in microsomes: 644 mL.min-1.g-1
Beside the measured number, compound 3's estimate is 2.2-fold (0.34 log units) above it; measured number outside the range, below it.
By their numbers in this assay, from the lowest: compounds 3 and 2 (each within the scatter of the next); then compound 1.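

In this assay the step of a 1.5-fold lower number from compound 2 to compound 3 (0.17 log units; within the scatter) does not separate the two compounds, so at this amide-type nitrogen the smaller pyridin-2-yl matches the larger group that carries the five-membered aromatic ring with 3 hetero atoms. Measured against 5-fluoro-2-methoxyphenyl, the change gives a 3.5-fold lower number from compound 1 to compound 3 (0.54 log units; beyond the scatter) and stays beyond the scatter, which shows that the slower clearance at this position does not need that five-membered ring or its hydrogen-bond donor. Nothing at hand explains either step.

As far as these compounds go, what a plain phenyl group or a pyrimidin-2-yl group would give at this nitrogen remains open, and with it whether the ring nitrogen of pyridin-2-yl counts at all. From the compounds shown here alone, all three compounds also keep the same four-carbon chain ending in phenyl on the amide, so it is unknown whether the result would hold with a shorter chain.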